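Chain extension on the free-amine aminodiol

The compounds below may be only part of what the source reports. "The series", "measured", "known", "first", "only" and "open" are said of these compounds alone.

Compound 3 `CCCCCCCCCCCCCC[C@H](N)[C@H](O)CO` gives the lowest number of the three measured in a functional assay on WiDr cells (Homo sapiens) for inhibition (a higher number here means a weaker inhibitor, a lower number a stronger inhibitor), namely 2760 nM. For the measured compounds named here, compound 2 `CCCCCCCCCCCCCC[C@H](NC(=O)OC(C)(C)C)[C@H](O)CO` gives 20800 nM in this assay, and the change a 7.5-fold lower number from compound 2 to compound 3 (0.88 log units; beyond the scatter) is the only one-place step among the measured compounds. Compound 1 `CCCCCCCCCCCCCCCCCC[C@@H](N)[C@@H](O)CO` gives 13300 nM in this assay; it differs from compound 3 in chain length and in the configuration at both stereocentres, so its value is noted only as a second point.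

Compound 4 `CCCCCCCCCCCCCCCCCC[C@H](N)[C@H](O)CO` carries the change (butyl in place of hydrogen on a saturated chain carbon, ten or more bonds along the chain from an amine nitrogen); the same difference, cut one bond further out, reads methyl to pentyl, ethyl to hexyl, propyl to heptyl. Going by the values given here, no measured step bears directly on this change: the only one-place step concerns the amine substituent, not the chain. The value of compound 1 shows that the longer chain, in the opposite configuration, sits above compound 3. For compound 4 the step is expected to be a 1.6-fold higher number from compound 3 to compound 4 (0.21 log units; within the scatter), a modest weakening. Compound 4 is therefore estimated at 4500 nM, with a range from 1200 nM to 17000 nM.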

Compound 4, half-maximal inhibitory concentration: 3470 nM
Beside the measured number, compound 4's estimate is 1.3-fold (0.11 log units) above it; low and high end bracket the measured number.
By their numbers in this assay, from the lowest: compounds 3 and 4 (each within the scatter of the next); then compounds 1 and 2 (each within the scatter of the next).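

In this assay, butyl in place of hydrogen on a saturated chain carbon, ten or more bonds along the chain from an amine nitrogen, gives a 1.3-fold higher number from compound 3 to compound 4 (0.10 log units; within the scatter), so in this configuration the added chain length does not separate the two compounds. Configuration does separate the long-chain pair, with a 3.8-fold lower number from compound 1 to compound 4 (0.58 log units; beyond the scatter). That gap can be assigned to the stereocentres taken together, because nothing else distinguishes the pair: the fact that compounds 1 and 4 differ only in the configuration as drawn

Still open, from the compounds shown here alone, is which of the two stereocentres carries the gap, and whether the level holds with a still longer chain or a phenyl group at the chain end. Also open, going by these compounds, is whether an acetyl group on the amine nitrogen would give a step like that seen with tert-butoxycarbonyl.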